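Linker change at the aniline ring: sulfonamide to amide

A few compounds are considered here, and "the series" means these few. Any claim that something is new, unique, unknown or untested is made for them only; others in the source may bear on it.

Measured so far:
compound 1 `CN(C)C(=O)c1cc2cnc(Nc3ccc(S(=O)(=O)NCCCN=C=S)cc3)nc2n1C1CCCC1`: 102%
compound 2 `CN(C)C(=O)c1cc2cnc(Nc3ccc(C(=O)NCCCCN=C=S)cc3F)nc2n1C1CCCC1`: 24.4%
compound 3 `CN(C)C(=O)c1cc2cnc(Nc3ccc(C(=O)NCCCCCN=C=S)cc3F)nc2n1C1CCCC1`: 15.6%

In a functional assay on A549 cells (Homo sapiens) for inhibition, read by CCK-8 assay, with a stated time of 72 h, tested at 10 uM (a higher number here means a stronger effect of the compound at the concentration tested, a lower number a weaker effect), compound 1 gives 102%, the highest of the three numbers. Compound 2 gives 24.4% and compound 3 gives 15.6%; both lie beyond the scatter below compound 1, compound 3 furthest.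

Compound 4 `CN(C)C(=O)c1cc2cnc(Nc3ccc(NC(=O)CCCCCN=C=S)cc3)nc2n1C1CCCC1` keeps the shared core and the isothiocyanate end but changes the link to the aromatic ring: a group of 11 heavy atoms (7 carbon, 2 nitrogen, 1 oxygen, 1 sulfur; no ring) in place of a group of 10 heavy atoms (4 carbon, 2 nitrogen, 2 oxygen, 2 sulfur; no ring), on an aromatic carbon

Going by the values given here, the one step between compounds differing in a single place, a number 8.8 percentage points lower from compound 2 to compound 3 (within the scatter), concerns only chain length and is within the scatter; it says nothing about the linker itself. Among the compounds with values here, compounds 2 and 3 both carry an amide-type link and give low numbers, but each also differs from compound 1 in a ring fluorine and in the chain, so no measured step isolates the linker change. The two amide-linked compounds sitting far below compound 1 nonetheless suggest a drop beyond the scatter for compound 4, with wide uncertainty.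

Compound 4 is therefore expected to give 45% in this assay, within 10% to 90%, which means an expected step of a number 57 percentage points lower from compound 1 to compound 4 (beyond the scatter).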

Compound 4, a percentage reported as inhibition, at one concentration (the size of the read-out at that concentration, not a potency): 100%
Estimate against measurement, compound 4: 55 percentage points below; measured number above the stated range.
By their numbers in this assay, from the lowest: compounds 3 and 2 (each within the scatter of the next); then compounds 4 and 1 (each within the scatter of the next).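

Going by these compounds alone, at the aromatic carbon para to a large group, the earlier compounds offered no single-place step, and the first one now reads a number 2 percentage points lower from compound 1 to compound 4 (within the scatter) in this assay, with the group of 11 heavy atoms and its amide-type link in place of the group of 10 heavy atoms and its sulfonamide link. This step holds at one concentration, where the percentage gives the size of the read-out and not a potency, while the pairs of compound 4 with compound 2 and with compound 3 differ in more than one place and cannot be read. No measurement at hand bears on what lies behind this result.

The compounds shown leave open what an amine in place of the isothiocyanate would give on the chain of compound 4, and what a longer or shorter chain would give on this same link. They also leave open whether compound 1 and compound 4 would stay within the scatter of each other at lower concentrations, or whether a ring fluorine on compound 4 would change its read-out.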